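Repositioning chlorine on the benzyl group of compound 3

The compounds below may be only part of what the source reports. "The series", "measured", "known", "first", "only" and "open" are said of these compounds alone.

Compound 3 `Clc1ccccc1Cn1cc(-c2ccccc2)c2c1CCNC2` gives the highest number of the three measured in an assay on HEK293 cells for displacement of a labelled ligand from 5-hydroxytryptamine receptor 7 (Rattus norvegicus), with a stated time of 60 min; a higher number here means a weaker inhibitor, a lower number a stronger inhibitor: compound 3 gives 22900 nM. Compound 1 `Clc1cccc(-c2cn(Cc3ccccc3)c3c2CNCC3)c1` gives 10000 nM, and compound 2 `COc1ccc(-c2cn(Cc3ccccc3)c3c2CNCC3)cc1` gives 290 nM. Within the data shown here, the only single-point step measured, a 34-fold lower number from compound 1 to compound 2 (1.54 log units; beyond the scatter), concerns the aryl group on the core, not the benzyl group, so it does not bear directly on the change considered here. Compound 4 `Clc1ccc(Cn2cc(-c3ccccc3)c3c2CCNC3)cc1` differs from compound 3 by 4-chlorophenyl in place of 2-chlorophenyl on a saturated chain carbon bound to an aromatic nitrogen. Among the measured compounds shown here, no measured pair isolates a change on the benzyl group; compound 3 differs from both compound 1 and compound 2 in two places, so those gaps cannot be assigned. With nothing to anchor the direction, a step within the scatter is expected for this assay , the expected change being a 1.5-fold lower number from compound 3 to compound 4 (0.18 log units; within the scatter). Compound 4 is therefore estimated at 15000 nM, with a range from 3000 nM to 50000 nM.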

Compound 4, inhibition constant: 753 nM
Compound 4: middle estimate off by 20-fold (1.30 log units), on the high side; the whole stated range lies above it.
By their numbers in this assay, from the lowest: compound 2; then compound 4; then compound 1; then compound 3.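

On the benzyl group, the place of the chlorine alone matters in this assay: 4-chlorophenyl in place of 2-chlorophenyl on a saturated chain carbon bound to an aromatic nitrogen gives a 30-fold lower number from compound 3 to compound 4 (1.48 log units; beyond the scatter) and leaves the atom content unchanged. Among these compounds, this is the first measured pair to isolate a change on this group, and it shows that the benzyl position responds, as the aryl group on the core does in a 34-fold lower number from compound 1 to compound 2 (1.54 log units; beyond the scatter), with both steps large. No evidence at hand accounts for the change.

Still open, going by these compounds, is how a bromine or a methoxy group in place of that chlorine would read, and whether a longer chain between the aromatic nitrogen and the 4-chlorophenyl would shift the number. Also open, on these data alone, is whether the 4-chlorophenyl of compound 4 and the 4-methoxyphenyl of compound 2 would combine favourably in a single compound.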